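A few compounds are considered here, and "the series" means these few. Any claim that something is new, unique, unknown or untested is made for them only; others in the source may bear on it.

In an ADME assay on MRC5 cells (Homo sapiens), read by MTT assay, with a stated time of 72 h (a higher number here means a weaker inhibitor, a lower number a stronger inhibitor), compound 1 `CNc1ncnc2c1c(-c1ccsc1)cn2[C@@H]1O[C@H](CO)[C@@H](O)[C@H]1O` gives > 100000 nM, which is a limit of the assay. Within the data shown here, compound 2 `Nc1nc2c(c(-c3ccoc3)cn2[C@@H]2O[C@H](CO)[C@@H](O)[C@H]2O)c(=O)[nH]1` gives 86100 nM, the only actual number so far. Compound 3 `Nc1nc2c(c(-c3cc4ccccc4o3)cn2[C@@H]2O[C@H](CO)[C@@H](O)[C@H]2O)c(=O)[nH]1` keeps the core of compound 2 and carries 1-benzofuran-2-yl in place of furan-3-yl on an aromatic carbon. Among the measured compounds shown here, no measured step covers such a change, so the expectation in this assay is only a moderate shift toward a lower number, meaning a stronger inhibitor. The expected change is a 2.9-fold lower number from compound 2 to compound 3 (0.46 log units; beyond the scatter). Compound 3 is estimated at 30000 nM, with an expected range of 6000 nM to 100000 nM.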

Compound 3, half-maximal inhibitory concentration: > 100000 nM
Compound 3 gave a limit, no number; the forecaster's own chance of this, stated with the estimate: 25%; at least 3.3-fold (0.52 log units) between middle value and limit.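

Setting 1-benzofuran-2-yl in place of furan-3-yl on an aromatic carbon gives the first step that can be read at this position in this assay, an at least 1.1-fold higher number from compound 2 to compound 3 (0.06 log units; that floor lies within the scatter). The added six-membered aromatic ring of carbon only brings no shift toward a lower number. Compound 3 gives a limit and not a number, so the step has a floor but no known size: the limit of > 100000 nM in this assay, at which 2 of the 3 values shown sit.

The compounds shown leave open how far past the limit compound 3 lies. They also leave open whether an amine or a carboxylic acid at this place would give a clearly lower number.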